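The source may hold more compounds than are shown below. What is called first, only, known or untested is meant among the compounds shown, and "the series" means these compounds.

Compound 2 `Cc1ccc(NC(=O)NC(=O)c2ccc(OCc3ccccc3)cc2)cc1-c1nc2ccccc2[nH]1` stands highest of the two numbers measured in a functional assay on MGC-803 cells (Homo sapiens) for inhibition, read by MTT assay, with a stated time of 48 h (a lower number here means a stronger inhibitor, a higher number a weaker inhibitor), where compound 2 gives 39400 nM. For the measured compounds named here, its only neighbour, compound 1 `O=C(NC(=S)Nc1ccc(Cl)c(-c2nc3ccccc3[nH]2)c1)c1ccc(OCc2ccc(C(F)(F)F)cc2)cc1`, gives 5330 nM in this assay, a lower number that lies beyond the usual scatter. Compound 3 `Cc1ccc(NC(=O)NC(=O)c2ccc(OCc3cccc(Cl)c3)cc2)cc1-c1nc2ccccc2[nH]1` differs from compound 2 in one place: chloro in place of hydrogen on an aromatic carbon. Going by the values given here, no measured pair shows this change on its own, so the expected step from compound 2 to compound 3 is small, likely toward a lower number and close to the scatter, as a 1.6-fold lower number from compound 2 to compound 3 (0.20 log units; within the scatter). Compound 3 is therefore estimated at 25000 nM, with a range from 8000 nM to 80000 nM.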

Compound 3, half-maximal inhibitory concentration: 20800 nM
Compound 3: the middle estimate sits 1.2-fold (0.08 log units) above what was measured; low and high end bracket the measured number.
By their numbers in this assay, from the lowest: compound 1; then compounds 3 and 2 (each within the scatter of the next).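

Replacing hydrogen with chloro on the benzyl ring, turning benzyl into 3-chlorobenzyl, gives in this assay a 1.9-fold lower number from compound 2 to compound 3 (0.28 log units; within the scatter), a step that stays within the usual scatter. This position therefore accepts a chlorine atom, but the pair shows no clear gain or loss in inhibition. No available information explains this result.

On these data alone, whether a methoxy group, an amine or a carboxylic acid at this carbon would move the number beyond the scatter remains open. So does the effect of chloro on the other carbons of this ring.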